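Repeated Aryl Swap and What It Suggests for Compound 4

The source may report more compounds than this note shows. Statements on the series, on what has been measured and on what is new or still open speak of the compounds shown alone.

Compound 1 `COc1ccc(/C=C/C(=O)C(=Cc2ccc(O)c(F)c2)C(=O)/C=C/c2ccc(OC)cc2OC)c(OC)c1` and compound 2 `COc1ccc(/C=C/C(=O)C(=Cc2cc(Br)c(O)c(OC)c2)C(=O)/C=C/c2ccc(OC)cc2OC)c(OC)c1` share one core. In a functional assay on CNE-2 cells (Homo sapiens) for antiproliferative activity, read by sulforhodamine B assay, with a stated time of 48 h (a lower number here means a stronger inhibitor, a higher number a weaker inhibitor), compound 1 gives 2830 nM, and compound 2 gives 1780 nM. The change between them is 3-bromo-4-hydroxy-5-methoxyphenyl in place of 3-fluoro-4-hydroxyphenyl on a double-bonded chain carbon bound to a double-bonded chain carbon, and it produced a 1.6-fold lower number from compound 1 to compound 2 (0.20 log units; within the scatter). Compound 3 `COc1cc(OC)c(/C=C/C(=O)C(=Cc2ccc(O)c(F)c2)C(=O)/C=C/c2c(OC)cc(OC)cc2OC)c(OC)c1` rests on another core; the difference between the core of compound 1 and the core of compound 3 is not broken down here. In this assay compound 3 gives 1580 nM. Compound 4 `COc1cc(OC)c(/C=C/C(=O)C(=Cc2cc(Br)c(O)c(OC)c2)C(=O)/C=C/c2c(OC)cc(OC)cc2OC)c(OC)c1` is not yet measured; it differs from compound 3 by 3-bromo-4-hydroxy-5-methoxyphenyl in place of 3-fluoro-4-hydroxyphenyl on a double-bonded chain carbon bound to a double-bonded chain carbon, the same change as that seen between compound 1 and compound 2. Because the earlier step was a 1.6-fold lower number from compound 1 to compound 2 (0.20 log units; within the scatter), a step of similar modest size is expected for compound 4 in this assay: a 1.6-fold lower number from compound 3 to compound 4 (0.20 log units; within the scatter). Compound 4 is accordingly estimated at 1000 nM, with a range from 500 nM to 2000 nM.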

Compound 4, half-maximal inhibitory concentration: 1320 nM
Beside the measured number, compound 4's estimate is 1.3-fold (0.12 log units) below it, within the range that was stated.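

On the core of compound 3 the change gives a 1.2-fold lower number from compound 3 to compound 4 (0.08 log units; within the scatter) in this assay. Set beside the step on the core of compound 1, it does not differ: the same change on two cores in this assay, a 1.6-fold lower number (0.20 log units; within the scatter) from compound 1 to compound 2 and a 1.2-fold lower number (0.08 log units; within the scatter) from compound 3 to compound 4, 1.3-fold (0.12 log units) apart, within the scatter of two such steps. This shows that 3-bromo-4-hydroxy-5-methoxyphenyl in place of 3-fluoro-4-hydroxyphenyl behaves alike on these two cores, but with both steps within the scatter it does not show that the change has any real effect on the number, and two cores establish no rule for the series.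

The compounds shown leave open how an aryl group carrying an amine or a carboxylic acid would read at that place. They also leave open whether the change would behave alike on any further core.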